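A few compounds are considered here, and "the series" means these few. Any claim that something is new, unique, unknown or untested is made for them only; others in the source may bear on it.

Measured in an assay on isolated protein for binding affinity to Neuropeptide Y receptor type 1 (Homo sapiens); on this read-out lower numbers stand for stronger inhibition and higher numbers for weaker inhibition:
compound 1 `Clc1ccc(OCc2nc3c(OCCC4CCNCC4)cccc3n2CCCC2CCCNC2)cc1` gives 7 nM
compound 2 `Clc1ccc(OCc2nc3c(OCCC4CCCNC4)cccc3n2CCCC2CCCNC2)cc1` gives 18 nM
compound 3 `Clc1ccc(OCc2nc3ccccc3n2CCCC2CCCNC2)cc1` gives 700 nM

Compound 3 carries the highest number of the three, with compound 2 nearest and compound 1 furthest from it. Compound 4 `Clc1ccc(OCc2nc3c(OCCCN4CCCCC4)cccc3n2CCCC2CCCNC2)cc1` differs from compound 3 by 3-(piperidin-1-yl)propoxy in place of hydrogen on an aromatic carbon. Among the compounds with values here, two measured steps bear on this change: removing a piperidine-bearing alkoxy chain from the same aromatic carbon gave a 100-fold higher number from compound 1 to compound 3 (2.00 log units; beyond the scatter) and a 39-fold higher number from compound 2 to compound 3 (1.59 log units; beyond the scatter), both large. Restoring such a chain is therefore expected to give a large step towards a lower number in this assay, although the chain of compound 4 is not the same as either measured one, which widens the range. Compound 4 is expected at 20 nM (range 5 nM to 90 nM), a step of a 35-fold lower number from compound 3 to compound 4 (1.54 log units; beyond the scatter).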

Compound 4, inhibition constant: 1.7 nM
Compound 4: middle estimate off by 12-fold (1.07 log units), on the high side, and the stated range ends above it.
By their numbers in this assay, from the lowest: compound 4; then compound 1; then compound 2; then compound 3.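

In this assay, the aromatic carbon accepts a chain joined through the piperidine nitrogen, with a 410-fold lower number from compound 3 to compound 4 (2.61 log units; beyond the scatter) as the largest step seen so far at this position. How the piperidine is attached still matters beyond the scatter, with a 4.1-fold lower number from compound 1 to compound 4 (0.61 log units; beyond the scatter) for the piperidin-4-yl chain and an 11-fold lower number from compound 2 to compound 4 (1.02 log units; beyond the scatter) for the piperidin-3-yl chain, although these steps also change the chain length and so do not isolate the attachment. No evidence here accounts for these differences.

Still open, on these data alone, is whether morpholine or dimethylamino could replace the terminal piperidine at this position. Also open, as far as these compounds go, is how a 4-(piperidin-1-yl)butoxy or 2-(piperidin-1-yl)ethoxy chain would compare with the 3-(piperidin-1-yl)propoxy chain.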